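From Difluorophenyl to Cyanophenyl: an Expected Potency Shift

A few compounds are considered here, and "the series" means these few. Any claim that something is new, unique, unknown or untested is made for them only; others in the source may bear on it.

Compound 1 `O=C(O)Cc1sc(C(c2ccc(F)cc2)c2ccc(F)cc2)nc1-c1cccc(F)c1`: 18 nM
Compound 2 `O=C(O)Cc1sc(C(c2ccc(F)cc2)c2ccc(F)cc2)nc1-c1cc(F)cc(F)c1`: 340 nM

In an in vitro functional assay on HEK285-7 cells for antagonist activity at prostaglandin D2 receptor 2 (Homo sapiens), read by BRET and beta-arrestin recruitment (a lower number here means a stronger inhibitor, a higher number a weaker inhibitor), compound 1 gives 18 nM and compound 2 gives 340 nM, so compound 2 stands highest of the two measured numbers. For the measured compounds named here, the one measured step, a 19-fold higher number from compound 1 to compound 2 (1.28 log units; beyond the scatter), is large. Compound 3 `N#Cc1ccc(-c2nc(C(c3ccc(F)cc3)c3ccc(F)cc3)sc2CC(=O)O)cc1` differs from compound 2 by 4-cyanophenyl in place of 3,5-difluorophenyl on an aromatic carbon. Going by the values given here, no measured step covers this exact swap; the earlier step shows only that the 3,5-difluorophenyl group came with a large penalty. As far as these compounds go, removing it may recover part of that loss, while the 4-cyanophenyl is untested, so for compound 3 a moderate gain is expected, a 4.9-fold lower number from compound 2 to compound 3 (0.69 log units; beyond the scatter), giving an estimated 70 nM (range 15 nM to 350 nM).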

Compound 3, half-maximal inhibitory concentration: 1500 nM
Estimate against measurement, compound 3: 21-fold (1.33 log units) below; measured number outside the range, above it.
By their numbers in this assay, from the lowest: compound 1; then compound 2; then compound 3.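

In this assay the 4-cyanophenyl group gives a 4.4-fold higher number from compound 2 to compound 3 (0.64 log units; beyond the scatter) and an 83-fold higher number from compound 1 to compound 3 (1.92 log units; beyond the scatter) so replacing the 3,5-difluorophenyl group does not by itself bring the number back down. Of the three groups shown at this position, 3-fluorophenyl gives the lowest number by a clear margin. Nothing available here explains the rise. As far as these compounds go, it stays open whether an unsubstituted phenyl, a 4-fluorophenyl or a 3-cyanophenyl group would keep the number low, and whether the loss with 4-cyanophenyl follows the nitrile itself or its place on the ring.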